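A few compounds are considered here, and "the series" means these few. Any claim that something is new, unique, unknown or untested is made for them only; others in the source may bear on it.

Among the compounds with values here, two chalcone-like compounds built on the same core have numbers so far. Compound 1 `COc1cc(-c2cc(/C=C/C(=O)c3ccc(N)cc3)[nH]n2)cc(OC)c1OC` gives 34000 nM in a functional assay on SNB-19 cells (Homo sapiens) for inhibition, read by sulforhodamine B assay, with a stated time of 48 h; on this read-out higher numbers stand for lower toxicity in this test and lower numbers for higher toxicity in this test. Compound 2 `COc1ccc(-c2cc(/C=C/C(=O)c3cc(OC)c(OC)c(OC)c3)[nH]n2)cc1OC` gives 27100 nM in this assay, the lowest of the two numbers, though the gap to compound 1 lies within the usual scatter, so the two read as one level.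

Compound 3 `COc1cc(C(=O)/C=C/c2cc(-c3cc(OC)c(OC)c(OC)c3)n[nH]2)cc(OC)c1OC` has not been measured in this assay. It differs from compound 2 by a single change: methoxy in place of hydrogen on an aromatic carbon. Both ends of compound 3 thus carry a trimethoxyphenyl, whereas in compound 2 one end carries a dimethoxyphenyl. Within the data shown here, no pair of measured compounds in this set shows the effect of this exact change, so there is nothing to anchor the size of the step other than the two values given.

With both numbers close together, the expectation for compound 3 is a step of a 1.1-fold lower number from compound 2 to compound 3 (0.04 log units; within the scatter) that stays within the scatter, with no clear direction. Compound 3 is therefore estimated at 25000 nM in this assay, with a range from 10000 nM to 60000 nM.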

Compound 3, concentration lethal to 50% of the cells: 8200 nM
For compound 3 the middle estimate is 3.0-fold (0.48 log units) above the measured one; measured number outside the range, below it.
By their numbers in this assay, from the lowest: compound 3; then compounds 2 and 1 (each within the scatter of the next).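

In this assay, within the data shown here, the step of a 3.3-fold lower number from compound 2 to compound 3 (0.52 log units; beyond the scatter) is the first change in one place to lie beyond the scatter, and it is modest in size. It shows that this aromatic carbon, ortho to a methoxy group and meta to a large group, is not indifferent to methoxy in place of hydrogen: the compound with a trimethoxyphenyl at both ends carries the lower number, which on this read-out stands for higher toxicity in this test. The evidence at hand offers no measurement that accounts for this step, which rests on a single pair of compounds.

Still open, on these data alone, is whether the drop belongs to methoxy itself or would also follow another group on the same carbon, such as a hydroxyl, an ethoxy or a fluorine. Among these compounds, equally open is whether methoxy in place of hydrogen would give a step of similar size at other aromatic carbons of the series, since no second pair with this change is at hand.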